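Swapping a thiazole for a methylthiophene on the amine arm

The source may report more compounds than this note shows. Statements on the series, on what has been measured and on what is new or still open speak of the compounds shown alone.

Two compounds share a core and differ only in the group hanging from the amine on the side chain. Compound 1 `COc1cccc(-c2c(C)n(Cc3c(F)cccc3F)c(=O)n(C[C@H](C)NCc3ccccc3)c2=O)c1F` carries a benzyl group on that amine; in an assay on HEK293 cells for binding affinity to Gonadotropin-releasing hormone receptor (Homo sapiens) (on this read-out lower numbers stand for stronger inhibition and higher numbers for weaker inhibition), compound 1 gives 25 nM. Compound 2 `COc1cccc(-c2c(C)n(Cc3c(F)cccc3F)c(=O)n(C[C@@H](C)NCc3nccs3)c2=O)c1F` carries a thiazolylmethyl group instead, and in this assay compound 2 gives 13 nM, the lower of the two numbers, although the step of a 1.9-fold lower number from compound 1 to compound 2 (0.28 log units; within the scatter) lies within the scatter.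

Compound 3 `COc1cccc(-c2c(C)n(Cc3c(F)cccc3F)c(=O)n(C[C@H](C)NCc3sccc3C)c2=O)c1F` is the next variation: 1-(((3-methylthiophen-2-yl)methyl)amino)ethyl in place of 1-(((1,3-thiazol-2-yl)methyl)amino)ethyl on a saturated chain carbon bound to an aromatic nitrogen. Among the measured compounds shown here, the only measured step that bears on it is the exchange of one aromatic arm for another in a 1.9-fold lower number from compound 1 to compound 2 (0.28 log units; within the scatter), and that exchange moved the number by no more than the scatter. The change from compound 2 to compound 3 is a similar exchange of one small aromatic arm for another, so no step beyond the scatter is expected, in either direction. Compound 3 is therefore estimated at 18 nM, with a range from 7 nM to 50 nM, an expected step of a 1.4-fold higher number from compound 2 to compound 3 (0.14 log units; within the scatter).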

Compound 3, inhibition constant: 4 nM
Beside the measured number, compound 3's estimate is 4.5-fold (0.65 log units) above it, and the stated range ends above it.
By their numbers in this assay, from the lowest: compound 3; then compounds 2 and 1 (each within the scatter of the next).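

Until this point, exchanging the aromatic arm on the side-chain amine had not moved the number beyond the scatter, so this position could have seemed indifferent to the change. The 3-methylthiophen-2-yl arm shows otherwise in this assay, with a 3.3-fold lower number from compound 2 to compound 3 (0.51 log units; beyond the scatter) and a 6.3-fold lower number from compound 1 to compound 3 (0.80 log units; beyond the scatter), so the choice of arm at this position can matter. Nothing measured here says why the number fell.

The ring and its methyl enter together, so a thiophen-2-yl arm without the methyl would be needed to separate their contributions. Going by these compounds, compound 2 is also drawn with the opposite configuration at the defined stereocentre from compound 1 and compound 3, so its step to compound 3 carries that difference as well, and what the configuration alone contributes stays open.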